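Removing the alkoxy group from the shared core

The compounds below may be only part of what the source reports. "The series", "measured", "known", "first", "only" and "open" are said of these compounds alone.

Compound 1 `COc1cc(/C=C2\SC(=O)NC2=O)ccc1OCN1C(=O)c2ccccc2C1=O` gives 35100 nM in an assay on isolated protein for inhibition of Alpha glucosidase (Homo sapiens), read by spectrophotometry, with stated times of 15 min and 30 min; a higher number here means a weaker inhibitor, a lower number a stronger inhibitor. Compound 2 `CCOc1cc(/C=C2\SC(=O)NC2=O)ccc1OCN1C(=O)c2ccccc2C1=O` gives 29300 nM in this assay, the lowest of the two numbers given, with compound 1 nearest; the step of a 1.2-fold lower number from compound 1 to compound 2 (0.08 log units; within the scatter). Compound 3 `O=C1NC(=O)/C(=C/c2cccc(OCN3C(=O)c4ccccc4C3=O)c2)S1` reaches only a limit in this assay, > 100000 nM, which is a limit and not a number (the limit of > 100000 nM in this assay, at which 1 of the 3 values shown sits). Compound 4 `O=C1NC(=O)/C(=C/c2ccc(OCN3C(=O)c4ccccc4C3=O)cc2)S1` differs from compound 2 in hydrogen in place of ethoxy on an aromatic carbon. For the measured compounds named here, only the step from compound 1 to compound 2 touches this group, and it stayed within the scatter, so no measured step shows what losing the group entirely does. Compound 4 is therefore expected to give a step of a 2.0-fold higher number from compound 2 to compound 4 (0.31 log units; beyond the scatter), toward weaker inhibition. The estimate for compound 4 in this assay is 60000 nM, in the range 25000 nM to 150000 nM.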

Compound 4, half-maximal inhibitory concentration: 25600 nM
Compound 4: the middle estimate sits 2.3-fold (0.37 log units) above what was measured; the range from low to high includes it.
By their numbers in this assay, from the lowest: compounds 4, 2 and 1 (each within the scatter of the next). At a limit, above all of these: compound 3.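

In this assay hydrogen in place of ethoxy gives a 1.1-fold lower number from compound 2 to compound 4 (0.06 log units; within the scatter) and hydrogen in place of methoxy gives a 1.4-fold lower number from compound 1 to compound 4 (0.14 log units; within the scatter) on the same aromatic carbon. Compound 1, compound 2 and compound 4 therefore read alike, so the alkoxy group at this position is not required for the inhibition seen in this series. Compound 3 remains a limit and not a number: the limit of > 100000 nM in this assay, at which 1 of the 4 values shown sits.

Still open, on these data alone, is whether any group here can move the number beyond the scatter. A longer chain, an amine or a carboxylic acid on this carbon would test that.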